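The source may hold more compounds than are shown below. What is called first, only, known or untested is meant among the compounds shown, and "the series" means these compounds.

Measured in a functional assay on OVCAR-8 cells (Homo sapiens) for antiproliferative activity; a higher number here means a weaker inhibitor, a lower number a stronger inhibitor:
- compound 1 `Cn1ncc(Cl)c1-c1cc(C(=O)N[C@@H]2CN[C@H](CCn3cncn3)C[C@H]2c2ccc(Cl)c(Cl)c2)oc1Cl`: 1560 nM
- compound 2 `Cn1ncc(Cl)c1-c1cc(C(=O)N[C@@H]2CN[C@H](CCO)C[C@H]2c2ccc(F)c(F)c2)oc1Cl`: 460 nM
- compound 3 `CC(=O)NCC[C@@H]1C[C@@H](c2ccc(F)c(F)c2)[C@H](NC(=O)c2cc(-c3c(Cl)cnn3C)c(Cl)o2)CN1`: 880 nM

Compound 1, at 1560 nM, cannot be separated from compound 3 within the usual scatter of repeat measurements, while compound 2 has a lower number, and that gap lies beyond the scatter. The next compound to test is compound 4 `Cn1ncc(Cl)c1-c1cc(C(=O)N[C@@H]2CN[C@H](CC(=O)NCC(O)CO)C[C@H]2c2ccc(Cl)c(Cl)c2)oc1Cl`. Its difference from compound 1 is this: (2,3-dihydroxypropyl)carbamoyl in place of (1H-1,2,4-triazol-1-yl)methyl on a saturated chain carbon bound to a saturated ring carbon. In words, (2,3-dihydroxypropyl)carbamoyl stands in place of (1H-1,2,4-triazol-1-yl)methyl on a saturated chain carbon bound to a saturated ring carbon.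

Within the data shown here, no measured step makes this exact swap. The closest guide is a change at the end of the same chain, a 1.9-fold higher number from compound 2 to compound 3 (0.28 log units; within the scatter). That pair also differs from compound 1 elsewhere in the structure, so it is only a loose guide. It gives no reason to expect a large shift, so no change beyond the scatter is expected. The expected step is a 1.2-fold lower number from compound 1 to compound 4 (0.08 log units; within the scatter). For compound 4 the estimated value is 1300 nM, with an expected range of 450 nM to 3500 nM.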

Compound 4, half-maximal inhibitory concentration: 5900 nM
The estimate for compound 4 lay 4.5-fold (0.66 log units) below the measured number; the measured number lies above the stated range.
By their numbers in this assay, from the lowest: compounds 2, 3 and 1 (each within the scatter of the next, the first and the last beyond it); then compound 4.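

In this assay, putting (2,3-dihydroxypropyl)carbamoyl in place of (1H-1,2,4-triazol-1-yl)methyl gives a 3.8-fold higher number from compound 1 to compound 4 (0.58 log units; beyond the scatter). Among these compounds, this shows that a change on this chain can move the number beyond the scatter, which the only earlier step on it, a 1.9-fold higher number from compound 2 to compound 3 (0.28 log units; within the scatter), did not show. Nothing here measures why compound 4 is the weaker inhibitor, and the swap changes several things at once, replacing an aromatic ring that has no hydrogen-bond donors with an open chain that has them.

Still open, from the compounds shown here alone, is which part of the entering group goes with the step: the carbamoyl or the two hydroxy groups of the dihydroxypropyl end. A plain carboxylic acid or a dimethylamino group at the same chain end would test how far the number depends on what sits there.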